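The source may report more compounds than this note shows. Statements on the series, on what has been measured and on what is new or still open speak of the compounds shown alone.

Measured compounds in a functional assay on AGS cells (Homo sapiens) for cytotoxicity, read by MTT assay, with a stated time of 48 h; on this read-out lower numbers stand for stronger inhibition and higher numbers for weaker inhibition:

Compound 1 `Cc1nc2c3ccccc3ccc2c2nc3c(ccc4ccccc43)c(-c3cccc([N+](=O)[O-])c3)c12` gives 25500 nM.
Compound 2 `Cc1nc2c3ccccc3ccc2c2nc3c(ccc4ccccc43)c(-c3nccnc3N)c12` gives 2260 nM.
Compound 3 `Cc1nc2c3ccccc3ccc2c2nc3c(ccc4ccccc43)c(-c3cccc4ccccc34)c12` gives 12100 nM.

Compound 3 stands second highest of the three numbers: its nearest neighbour is compound 1, with a 2.1-fold lower number from compound 1 to compound 3 (0.32 log units; beyond the scatter), and its furthest is compound 2, with a 5.4-fold higher number from compound 2 to compound 3 (0.73 log units; beyond the scatter). All three share the same core and differ only in the aromatic group attached to one carbon of that core.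

Compound 4 `Cc1nc2c3ccccc3ccc2c2nc3c(ccc4ccccc43)c(-c3cc([N+](=O)[O-])ccc3N)c12` is that core carrying a further variant of this group: 2-amino-5-nitrophenyl in place of naphthalen-1-yl on an aromatic carbon.

For the measured compounds named here, two measured steps bear on this change. Replacing 3-nitrophenyl with naphthalen-1-yl gave a 2.1-fold lower number from compound 1 to compound 3 (0.32 log units; beyond the scatter), a modest move, while replacing 3-aminopyrazin-2-yl with naphthalen-1-yl gave a 5.4-fold higher number from compound 2 to compound 3 (0.73 log units; beyond the scatter). The entering 2-amino-5-nitrophenyl group carries both a nitro group, as in compound 1, and an amino group, as in compound 2. Compound 1 gives the highest number and compound 2 the lowest, so a group holding both features is expected to land between them, which means a modest downward step is expected from compound 3, a 2.0-fold lower number from compound 3 to compound 4 (0.30 log units; within the scatter).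

Compound 4 is therefore estimated at 6000 nM, with a range from 2000 nM to 20000 nM.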

Compound 4, half-maximal inhibitory concentration: 17800 nM
Beside the measured number, compound 4's estimate is 3.0-fold (0.47 log units) below it; the range from low to high includes it.
By their numbers in this assay, from the lowest: compound 2; then compounds 3, 4 and 1 (each within the scatter of the next, the first and the last beyond it).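

In this assay, placing an amino group on the 3-nitrophenyl ring of compound 1 gives a 1.4-fold lower number from compound 1 to compound 4 (0.16 log units; within the scatter), which lies within the usual scatter, so this single addition has no readable effect at this position. Compound 4 is also within the scatter of compound 3, with a 1.5-fold higher number from compound 3 to compound 4 (0.17 log units; within the scatter), even though a single ring carrying amino and nitro groups has replaced the two rings of naphthalen-1-yl. Compound 2 stays clearly apart, with a 7.9-fold higher number from compound 2 to compound 4 (0.90 log units; beyond the scatter), so an amino group on the attached ring is not enough to bring the number down to that of compound 2.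

No supporting data explain why 3-aminopyrazin-2-yl stands apart from the other groups. The 2-amino-5-nitrophenyl group differs from 3-aminopyrazin-2-yl both in its nitro group and in having no ring nitrogens, so the shown compounds cannot separate these two differences; a plain 2-aminophenyl group or a 2-aminopyridin-3-yl group at the same carbon would address that question.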